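Swapping the formyl for a carboxypyrrolidinylmethyl: cytotoxicity outlook

A few compounds are considered here, and "the series" means these few. Any claim that something is new, unique, unknown or untested is made for them only; others in the source may bear on it.

Compound 1 `COc1ccc(/C=C\c2cc(OC)c(OC)c(OC)c2)cc1OCc1ccc(C=O)cc1` carries a formyl group on the shared core. Going by the values given here, in an ADME assay on NCM460 cells (Homo sapiens) for cytotoxicity, read by CCK-8 assay, with a stated time of 48 h (on this read-out higher numbers stand for weaker inhibition and lower numbers for stronger inhibition), compound 1 gives 41000 nM, the only value in this set that is a number. Compound 2 `COc1ccc(/C=C\c2cc(OC)c(OC)c(OC)c2)cc1OCc1ccc(CN2C[C@H](O)C[C@@H]2C(=O)O)cc1` reaches only a limit of the assay in this assay, at > 50000 nM. Compound 3 `COc1ccc(/C=C\c2cc(OC)c(OC)c(OC)c2)cc1OCc1ccc(CN2CC[C@H](C(=O)O)C2)cc1` likewise returns a limit in this assay, at > 50000 nM. Both of these therefore sit at the limit of > 50000 nM in this assay, at which 2 of the 3 values shown sit.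

Compound 4 `COc1ccc(/C=C\c2cc(OC)c(OC)c(OC)c2)cc1OCc1ccc(CN2CC[C@@H](C(=O)O)C2)cc1` is not yet measured. It differs from compound 1 by (3-carboxypyrrolidin-1-yl)methyl in place of formyl on an aromatic carbon. The measured steps that bear on this change are an at least 1.2-fold higher number from compound 1 to compound 2 (0.08 log units; that floor lies within the scatter) and an at least 1.2-fold higher number from compound 1 to compound 3 (0.08 log units; that floor lies within the scatter), each of them a floor only, with the true step unreadable. On that basis the change is expected to shift the read-out toward weaker inhibition or leave it within the scatter, the estimated step being a 1.5-fold higher number from compound 1 to compound 4 (0.17 log units; within the scatter). Compound 4 is therefore estimated at 60000 nM, within a range from 35000 nM to 120000 nM, most likely reported as a limit.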

Compound 4, half-maximal inhibitory concentration: > 50000 nM
Compound 4: a limit, no number (the forecaster's own chance of this, stated with the estimate: 70%); the middle value lies beyond the limit too.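

Compound 4 adds the other drawn configuration at the saturated ring carbon, and in this assay replacing formyl with (3-carboxypyrrolidin-1-yl)methyl again gives an at least 1.2-fold higher number from compound 1 to compound 4 (0.08 log units; that floor lies within the scatter). Both drawn configurations of this group now end at a limit of the assay, but the steps among compound 2, compound 3 and compound 4 cannot be read, so no effect of configuration can be told: the fact that compounds 3 and 4 differ only in the configuration as drawn The set now gathers at a single limit, leaving compound 1 as the only compound with a number: the limit of > 50000 nM in this assay, at which 3 of the 4 values shown sit.

From the compounds shown here alone, the true size of the step from the formyl group to the carboxypyrrolidinylmethyl group stays open. Also open, going by these compounds, is whether a piperidine ring or a primary amine at this position would give a number rather than a limit.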